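This account rests on a few compounds, and the source may have more. Where it says the series, first, only, none or still open, it means among the compounds named here.

In an ADME assay on HEK293 cells (Homo sapiens) for cytotoxicity, read by resazurin assay, with a stated time of 48 h (a higher number here means that more compound is tolerated, a lower number that less compound is tolerated), compound 1 `O=S(=O)(Nc1ccc2oc(-c3ccccc3)nc2c1)c1ccccc1Cl` gives 73000 nM and compound 2 `Cc1cccc(S(=O)(=O)Nc2ccc3oc(-c4ccccc4)nc3c2)c1` gives 69000 nM with the two numbers within the scatter of each other, so compound 2 has no standing apart from compound 1 on these data. Compound 3 `CS(=O)(=O)Nc1ccc2oc(-c3ccccc3)nc2c1` has not yet been measured. Its difference from compound 2 is methyl in place of 3-methylphenyl on a sulfonyl sulfur and in words this is methyl in place of 3-methylphenyl on a sulfonyl sulfur. For the measured compounds named here, the one measured step that bears on this is a 1.1-fold lower number from compound 1 to compound 2 (0.02 log units; within the scatter) for 3-methylphenyl in place of 2-chlorophenyl on a sulfonyl sulfur, and it stays within the scatter. Going by the values given here, both groups in that step carry a ring, while no measured compound lacks a ring at this place, so the step covers the new change only weakly. A step beyond the scatter in this assay is not expected, no firm direction can be argued, and the range is kept wide for that reason. The expected step is a 1.2-fold higher number from compound 2 to compound 3 (0.06 log units; within the scatter) on this estimate. For compound 3 the estimated value is 80000 nM with an expected range from 40000 nM to 160000 nM around it.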

Compound 3, half-maximal cytotoxic concentration: > 100000 nM
Compound 3: no number, only a limit; the forecaster's own chance of this, stated with the estimate: 30%; middle value at least 1.2-fold (0.09 log units) from the limit.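

For the compounds shown here, with methyl on the sulfonyl sulfur, where the earlier compounds carry an aromatic ring, compound 3 gives > 100000 nM in this assay, and this value is a limit of the assay, not a number: the limit of > 100000 nM in this assay, at which 1 of the 3 values shown sits. The comparisons therefore give floors only, an at least 1.4-fold higher number from compound 2 to compound 3 (0.16 log units; that floor lies within the scatter) and an at least 1.3-fold higher number from compound 1 to compound 3 (0.13 log units; that floor lies within the scatter), so neither establishes a change beyond the scatter. Going by these compounds alone, what is new is that this position has now been read without a ring, and a methyl group here gives no sign of less compound being tolerated than with 3-methylphenyl or 2-chlorophenyl.

As far as these compounds go, the true size of both steps stays open, as does whether compound 3 truly separates from compound 1 and compound 2 in this assay. Also open, from the compounds shown here alone, is how this position responds to groups between methyl and an aromatic ring in size, such as a longer chain like propyl, or to a group carrying an amine or a carboxylic acid on the sulfonyl sulfur.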